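The compounds below may be only part of what the source reports. "The series", "measured", "known", "first", "only" and "open" are said of these compounds alone.

In a functional assay on RD cells (Homo sapiens) for inhibition, read by luminescence and ATP content, with a stated time of 72 h (a higher number here means that more compound is tolerated, a lower number that less compound is tolerated), compound 3 `CCc1ccc(-c2ccc3ncc(-c4noc(CC)n4)cc3c2)cc1` gives > 22200 nM, which is a limit of the assay rather than a number. Compound 1 `CCc1ccc(-c2ccc3ncc(-c4noc(C)n4)cc3c2)cc1` gives > 7400 nM, likewise a limit. Compound 2 `CCc1nc(-c2cnc3ccc(-c4ccc(N)nc4)cc3c2)no1` gives > 66700 nM, also a limit. The two neighbouring steps, a step that the two limits leave unreadable from compound 1 to compound 3 and a step that the two limits leave unreadable from compound 2 to compound 3, consequently cannot be sized: the limit of > 22200 nM in this assay, at which 1 of the 3 values shown sits, the limit of > 66700 nM in this assay, at which 1 of the 3 values shown sits, and the limit of > 7400 nM in this assay, at which 1 of the 3 values shown sits, are all the series shows. Compound 4 `CCc1nc(-c2cnc3ccc(-c4ccc(F)cc4)cc3c2)no1` carries the change (fluoro in place of ethyl on an aromatic carbon); cut one bond further out it reads 4-ethylphenyl to 4-fluorophenyl. Among the compounds with values here, no measured step bears readably on this change, so nothing beyond the scatter is expected in this assay. A step that the limit leaves unreadable from compound 3 to compound 4 is expected. Compound 4 is estimated at 30000 nM, between 10000 nM and 100000 nM, most probably reported again only as a limit.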

Compound 4, half-maximal cytotoxic concentration: > 7400 nM
Compound 4: a limit, no number (the forecaster's own chance of this, stated with the estimate: 80%); the middle value lies beyond the limit too.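

In this assay compound 4 gives > 7400 nM, a limit and not a number; its steps from compound 2 and compound 3 cannot be read. Left open is where the half-maximal cytotoxic concentration of compound 1, compound 2, compound 3 or compound 4 actually lies, and whether fluoro in place of ethyl shifts it at all.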